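The source may hold more compounds than are shown below. What is called first, only, known or untested is meant among the compounds shown, and "the series" means these compounds.

In a functional assay on HT-29 cells (Homo sapiens) for inhibition, read by luminescence and CellTiter-Glo, with a stated time of 24 h (on this read-out higher numbers stand for an effect only at larger amounts of compound and lower numbers for an effect already at smaller amounts), compound 1 `CCCCCn1nc(C(=O)N[C@H]2COc3ccccc3N(C)C2=S)nc1Cc1ccccc1` gives 805 nM, while compound 2 `CN1C(=S)[C@@H](NC(=O)c2nc(Cc3ccccc3)n(C3CCCC3)n2)COc2ccccc21` gives 3530 nM, the higher of the two numbers. Among the measured compounds shown here, the one measured step is a 4.4-fold higher number from compound 1 to compound 2 (0.64 log units; beyond the scatter), with cyclopentyl in place of pentyl on an aromatic nitrogen. Compound 3 `CN1C(=S)[C@@H](NC(=O)c2nc(Cc3ccccc3)n(C3COC3)n2)COc2ccccc21` changes that same place, with oxetan-3-yl in place of cyclopentyl on an aromatic nitrogen. A single step is thin evidence, but a modest further rise seems likely, given the size of a 4.4-fold higher number from compound 1 to compound 2 (0.64 log units; beyond the scatter). The expected change is a 2.0-fold higher number from compound 2 to compound 3 (0.30 log units; within the scatter). For compound 3 the estimated value is 7000 nM, within an expected range of 2500 nM to 20000 nM.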

Compound 3, half-maximal effective concentration: 916 nM
Compound 3: middle estimate off by 7.6-fold (0.88 log units), on the high side, and the stated range ends above it.
By their numbers in this assay, from the lowest: compounds 1 and 3 (each within the scatter of the next); then compound 2.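

Oxetan-3-yl in place of cyclopentyl gives a 3.9-fold lower number from compound 2 to compound 3 (0.59 log units; beyond the scatter) in this assay, so a ring on this aromatic nitrogen does not by itself go with the higher number. With oxetan-3-yl in place of pentyl, the result is a 1.1-fold higher number from compound 1 to compound 3 (0.06 log units; within the scatter), so this ring and the open chain cannot be told apart here. The data offer no explanation for the difference between the two rings. Still open, from the compounds shown here alone, is whether the oxygen or the smaller ring goes with the lower number, since the two change together. Cyclobutyl on this nitrogen would separate them.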